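Vero Cell Cytotoxicity of Chalcone Amides: Towards a Methylphenyl Analogue

This account rests on a few compounds, and the source may have more. Where it says the series, first, only, none or still open, it means among the compounds named here.

Compound 1, `COC(=O)c1cc(-c2cccc(NC(=O)c3ccc(/C=C/C(=O)c4cc(OC)c(OC)c(OC)c4)cc3)c2)on1`: in an ADME assay on Vero cells (Chlorocebus sabaeus) for cytotoxicity, read by MTT assay, with a stated time of 72 h (on this read-out higher numbers stand for lower toxicity in this test and lower numbers for higher toxicity in this test), compound 1 gives > 50 ug/mL, a limit of the test.
Compound 2, `COC(=O)c1cc(-c2cccc(NC(=O)c3ccc(/C=C/C(=O)c4ccc(C)c(F)c4)cc3)c2)on1`: in this assay compound 2 gives > 50 ug/mL, a limit of the test.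
Compound 3, `COC(=O)c1cc(-c2cccc(NC(=O)c3ccc(/C=C/C(=O)c4cccc(Br)c4)cc3)c2)on1`: in this assay compound 3 gives > 100 ug/mL, a limit of the test.

Compound 3 sits at the limit of > 100 ug/mL in this assay, at which 1 of the 3 values shown sits. Compound 1 and compound 2 sit at the limit of > 50 ug/mL in this assay, at which 2 of the 3 values shown sit. Because all three are limits, the steps a step that the two limits leave unreadable from compound 1 to compound 3, a step that the two limits leave unreadable from compound 2 to compound 3 and a step that the two limits leave unreadable from compound 1 to compound 2 cannot be read in size. Compound 4 is `COC(=O)c1cc(-c2cccc(NC(=O)c3ccc(/C=C/C(=O)c4ccccc4C)cc3)c2)on1`, and its change from compound 3 is 2-methylphenyl in place of 3-bromophenyl on a carbonyl carbon. With every measured step unreadable, nothing points to a shift in either direction, so the expected step of a number no higher from compound 3 to compound 4 (the limit leaves the size open) is none beyond the scatter. Compound 4 is therefore estimated at 100 ug/mL in this assay, within 50 ug/mL to 200 ug/mL.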

Compound 4, half-maximal cytotoxic concentration: > 25 ug/mL
Compound 4: no number, only a limit; the forecaster's own chance of this, stated with the estimate: 80%; the middle value is on the limit's open side.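

In this assay compound 4 gives > 25 ug/mL, a limit of the test. The steps to compound 4 from compound 1, compound 2 and compound 3 cannot be read in size. The compounds shown leave open whether changing the group on the carbonyl carbon alters cytotoxicity at all.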